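The compounds below may be only part of what the source reports. "The series", "measured", "known", "first", "only" and "open" are said of these compounds alone.

Working notes on the series. Three members have so far been run in an assay on T-REx-293 cells for inhibition of potassium channel subfamily T member 1 (Homo sapiens), read by patch clamp; a lower number here means a stronger inhibitor, a higher number a weaker inhibitor. Compound 1 `Cc1cncc(-c2noc([C@H](C)NC(=O)c3cc(C(F)(F)F)nn3C)n2)c1` gives 1370 nM, the highest number of the three, with both other compounds beyond the scatter below it. Compound 2 `C[C@H](NC(=O)c1cc(C(F)(F)F)nn1C)c1nc(-c2ccnc(C3CC3)c2)no1` gives 16 nM and compound 3 `CNc1cc(-c2noc([C@H](C)NC(=O)c3cc(C(F)(F)F)nn3C)n2)ccn1` gives 195 nM. The step of an 86-fold lower number from compound 1 to compound 2 (1.93 log units; beyond the scatter) and the step of a 7.0-fold lower number from compound 1 to compound 3 (0.85 log units; beyond the scatter) both run downward, and the gap between them, a 12-fold higher number from compound 2 to compound 3 (1.09 log units; beyond the scatter), shows how strongly the group carried on the pyridine ring sets the result.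

Compound 4 `CO[C@@H](C)c1cc(-c2noc([C@H](C)NC(=O)c3cc(C(F)(F)F)nn3C)n2)ccn1` has not yet been run in this assay. Against compound 1 it differs by a group of 10 heavy atoms (8 carbon, 1 nitrogen, 1 oxygen; one six-membered aromatic ring with 1 hetero atom) in place of a group of 7 heavy atoms (6 carbon, 1 nitrogen; one six-membered aromatic ring with 1 hetero atom), on an aromatic carbon. The two measured steps that bear on this change are those from the 5-methylpyridin-3-yl of compound 1 to 2-cyclopropylpyridin-4-yl and to 2-(methylamino)pyridin-4-yl, one large and one modest, both lowering the number beyond the scatter. The entering group of compound 4 is again a pyridin-4-yl carrying a group, so a downward step is expected, placed between the two measured ones because an 86-fold lower number from compound 1 to compound 2 (1.93 log units; beyond the scatter) and a 7.0-fold lower number from compound 1 to compound 3 (0.85 log units; beyond the scatter) bracket the plausible outcome. For compound 4 a step of a 14-fold lower number from compound 1 to compound 4 (1.14 log units; beyond the scatter) is expected, giving an estimated 100 nM with a range from 25 nM to 400 nM.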

Compound 4, half-maximal inhibitory concentration: 744 nM
The estimate for compound 4 lay 7.4-fold (0.87 log units) below the measured number; measured number outside the range, above it.
By their numbers in this assay, from the lowest: compound 2; then compound 3; then compounds 4 and 1 (each within the scatter of the next).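

In this assay a pyridin-4-yl ring carrying a group is not enough on its own to separate a compound from compound 1: with 1-methoxyethyl on that ring, a 1.8-fold lower number from compound 1 to compound 4 (0.27 log units; within the scatter) stays within the scatter, so the 5-methylpyridin-3-yl and this larger group cannot be told apart here. What the group on the pyridin-4-yl ring decides shows in the other two steps, both beyond the scatter, with 1-methoxyethyl in place of methylamino giving a 3.8-fold higher number from compound 3 to compound 4 (0.58 log units; beyond the scatter) and 1-methoxyethyl in place of cyclopropyl giving a 47-fold higher number from compound 2 to compound 4 (1.67 log units; beyond the scatter) as the larger of the two. Among the three pyridin-4-yl compounds, cyclopropyl therefore stands at the lowest number and 1-methoxyethyl at the highest, with methylamino in the middle, and this order covers these three groups only.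

The compounds shown leave open whether the result belongs to the methoxy oxygen, the branching or the defined stereocentre of 1-methoxyethyl, which the opposite stereoisomer, an ethyl group or a methoxymethyl group on the same ring would help to separate. Nothing available on these compounds accounts for the differences between these groups.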